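From benzyl to cyclopentyl on the amide nitrogen

A few compounds are considered here, and "the series" means these few. Any claim that something is new, unique, unknown or untested is made for them only; others in the source may bear on it.

Measured so far in a functional assay on A549 cells (Homo sapiens) for inhibition, read by sulforhodamine B assay, with a stated time of 72 h; on this read-out higher numbers stand for weaker inhibition and lower numbers for stronger inhibition:
compound 1 `Nc1sc(-c2ccc(Cl)cc2)c(-c2ccc(Cl)cc2)c1C(=O)NC1CCCCC1` gives 2410 nM
compound 2 `Nc1sc(-c2ccc(Cl)cc2)c(-c2ccc(Cl)cc2)c1C(=O)NCc1ccccc1` gives 16300 nM

Compound 2 has the higher number of the two, so it is the weaker inhibitor. Compound 3 `Nc1sc(-c2ccc(Cl)cc2)c(-c2ccc(Cl)cc2)c1C(=O)NC1CCCC1` keeps the shared core but carries cyclopentyl in place of benzyl on an amide-type nitrogen. Among the measured compounds shown here, one measured step bears on this change: a 6.8-fold higher number from compound 1 to compound 2 (0.83 log units; beyond the scatter) with benzyl in place of cyclohexyl. Cyclopentyl, a non-aromatic ring of carbon only, resembles the cyclohexyl of compound 1 (2410 nM) more than benzyl does. A step of similar size toward a lower number is therefore expected in this assay and the estimated step is a 4.7-fold lower number from compound 2 to compound 3 (0.67 log units; beyond the scatter) in this reading. Compound 3 is expected at 3500 nM within an estimated range of 1500 nM to 9000 nM overall.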

Compound 3, half-maximal inhibitory concentration: 6790 nM
The estimate for compound 3 lay 1.9-fold (0.29 log units) below the measured number; low and high end bracket the measured number.
By their numbers in this assay, from the lowest: compound 1; then compound 3; then compound 2.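

In this assay the change to cyclopentyl gives a 2.4-fold lower number from compound 2 to compound 3 (0.38 log units; beyond the scatter), so replacing benzyl with a non-aromatic carbon ring lowers the number here too. Yet the two non-aromatic rings are not interchangeable: a 2.8-fold higher number from compound 1 to compound 3 (0.45 log units; beyond the scatter) shows that cyclopentyl falls short of cyclohexyl, placing compound 3 between the other two compounds. Nothing available explains this order. Still open, from the compounds shown here alone, is whether a larger ring such as cycloheptyl would lower the number further, and how an open chain such as n-hexyl on the amide nitrogen would compare.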